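The source may hold more compounds than are shown below. What is called first, only, known or untested is meant among the compounds shown, and "the series" means these compounds.

Three measured compounds and one unmeasured compound are compared in a functional assay on MCF7 cells (Homo sapiens) for cytotoxicity, read by MTT assay, with a stated time of 48 h; on this read-out higher numbers stand for weaker inhibition and lower numbers for stronger inhibition. Compound 1 `CC(C)=CCC/C(C)=C/CC/C(C)=C/CC[C@@H]1[C@@]2(C)CC/C(=N\OCc3cn(-c4cccc(Br)c4)nn3)C(C)(C)[C@@H]2CC[C@@]1(C)O` bears a 3-bromophenyl group on an aromatic nitrogen of a five-membered aromatic ring with 3 nitrogen; in this assay compound 1 gives 24800 nM. Compound 2 `CC(C)=CCC/C(C)=C/CC/C(C)=C/CC[C@@H]1[C@@]2(C)CC/C(=N\OCc3cn(-c4ccccc4C#N)nn3)C(C)(C)[C@@H]2CC[C@@]1(C)O` differs from compound 1 in one place: 2-cyanophenyl in place of 3-bromophenyl on an aromatic nitrogen. In this assay compound 2 gives 24900 nM. That change produced a step of a 1.0-fold higher number from compound 1 to compound 2 (0.00 log units; within the scatter), so the two numbers cannot be distinguished here. Compound 3 `CC(C)=CCC/C(C)=C/CC/C(C)=C/CC[C@@H]1[C@@]2(C)C/C(=C\c3ccc(OCc4cn(-c5cccc(Br)c5)nn4)cc3)C(=O)C(C)(C)[C@@H]2CC[C@@]1(C)O` carries the same 3-bromophenyl group on the same kind of ring but on a different core; the difference between the core of compound 1 and the core of compound 3 is not broken down here. In this assay compound 3 gives 61000 nM, the highest of the three numbers, and its steps to compound 2 and to compound 1 both lie beyond the scatter.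

Compound 4 `CC(C)=CCC/C(C)=C/CC/C(C)=C/CC[C@@H]1[C@@]2(C)C/C(=C\c3ccc(OCc4cn(-c5ccccc5C#N)nn4)cc3)C(=O)C(C)(C)[C@@H]2CC[C@@]1(C)O` has not yet been measured. It differs from compound 3 by 2-cyanophenyl in place of 3-bromophenyl on an aromatic nitrogen, the same change already seen between compound 1 and compound 2, at a place described in identical words. Because the earlier step of a 1.0-fold higher number from compound 1 to compound 2 (0.00 log units; within the scatter) stayed within the scatter, a similar outcome is expected on the new core. The expected step is estimated at no change at the digits printed from compound 3 to compound 4 (within the scatter). This rests on a single pair, so the expectation is loosely held. In this assay compound 4 is expected to give about 61000 nM, within an estimated range from 30000 nM to 125000 nM.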

Compound 4, half-maximal inhibitory concentration: 29900 nM
Beside the measured number, compound 4's estimate is 2.0-fold (0.31 log units) above it; measured number below the stated range.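

In this assay, putting 2-cyanophenyl in place of 3-bromophenyl gave a 2.0-fold lower number from compound 3 to compound 4 (0.31 log units; beyond the scatter), a modest move towards stronger inhibition, whereas the same change on the core of compound 1 gave a 1.0-fold higher number from compound 1 to compound 2 (0.00 log units; within the scatter). Read at face value, the change did something on one core and nothing on the other, but the gap between the two steps is too small to show that the core matters: the same change on two cores in this assay, a 1.0-fold higher number (0.00 log units; within the scatter) from compound 1 to compound 2 and a 2.0-fold lower number (0.31 log units; beyond the scatter) from compound 3 to compound 4, 2.0-fold (0.31 log units) apart, within the scatter of two such steps. Within the data shown here, this does not prove that the change behaves alike on both cores, and it does not establish a real gain from it, as only one pair per core is available and the step on the second core is modest.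

The compounds shown leave open how other groups on the aromatic nitrogen of the same ring would behave on these two cores, such as an unsubstituted phenyl, a benzyl group or a short alkyl chain. They also leave open whether a group carrying an amine or a carboxylic acid at this place would shift the numbers further than the two groups compared here.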